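Swapping an ether arm for a fluorophenyl chain

The source may hold more compounds than are shown below. What is called first, only, known or untested is meant among the compounds shown, and "the series" means these compounds.

Going by the values given here, compound 2 `CN1CCC(c2ccc3c(c2)oc(=O)n3C(=O)NCCOCc2ccccc2)CC1` is the only compound here with a plain number: in an ADME assay on microsomes from liver (Mus musculus) for metabolic stability, read by LC-MS, using NADPH, with stated times of 15 min and 60 min, tested at 4.6 uM (on this read-out lower numbers stand for a shorter-lived compound and higher numbers for a longer-lived compound), compound 2 gives 0.5 h. Compound 1 `CC(C)CNC(=O)n1c(=O)oc2cc(C3CCN(C)CC3)ccc21` reaches the upper limit of the assay, where compound 1 gives > 1 h, a limit rather than a number (the limit of > 1 h in this assay, at which 1 of the 2 values shown sits). Among the compounds with values here, the one measured step, an at least 2.0-fold lower number from compound 1 to compound 2 (0.30 log units; that floor lies within the scatter), changes a group at a different point of the chain than the change now in question, so it bears on it only loosely. Compound 3 `CN1CCC(c2ccc3c(c2)oc(=O)n3C(=O)NCCCCc2ccc(F)cc2)CC1` differs from compound 2 by 2-(4-fluorophenyl)ethyl in place of benzyloxy on a saturated chain carbon, two bonds along the chain from an amide-type nitrogen. Within the data shown here, no measured pair shows what trading an ether-containing arm for a longer all-carbon arm does in this assay, so the expectation leans on compound 2 itself. Compound 3 is therefore expected to stay near the value of compound 2, with an estimated step of no change at the digits printed from compound 2 to compound 3 (within the scatter), giving an estimate of 0.5 h within a range from 0.25 h to 1 h.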

Compound 3, half-life in the Mus musculus assay: 0.5 h
Estimate against measurement, compound 3: no gap at the digits printed; measured number inside the range.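

In the Mus musculus assay, replacing benzyloxy with 2-(4-fluorophenyl)ethyl gives no change at the digits printed from compound 2 to compound 3 (within the scatter), so at this place on the chain the ether-containing arm and the all-carbon arm cannot be told apart on half-life. The step of an at least 2.0-fold lower number from compound 1 to compound 3 (0.30 log units; that floor lies within the scatter) starts from the value of compound 1, which is a limit and not a number, so it gives only a floor. The two arms do separate in another measurement: in a physicochemical assay for solubility, read by HPLC, in phosphate buffer, measured as kinetic solubility, with a stated time of 1 h, at pH 7.4, tested at 250 uM (a higher number here means a more soluble compound, a lower number a less soluble compound), compound 2 gives 73000 nM and compound 3 gives 22000 nM, which is a 3.3-fold lower number from compound 2 to compound 3 (0.52 log units; beyond the scatter).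

The oxygen leaves and the fluorine enters in the same change, so these structures cannot show which of the two goes with the difference in solubility. Also open, as far as these compounds go, is how an arm ending in an amine or a carboxylic acid would behave at this place.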